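A small ring on a weak inhibitor

The source may report more compounds than this note shows. Statements on the series, on what has been measured and on what is new or still open speak of the compounds shown alone.

Of the compounds shown here, three have been measured in a functional assay on L02 cells (Homo sapiens) for inhibition, read by Griess assay, with stated times of 1 h and 24 h; a higher number here means a weaker inhibitor, a lower number a stronger inhibitor. Among the measured compounds shown here, compound 1 `CCCc1nn(C)c2c(NC3CC3)nc(CCc3cccnc3)nc12` gives 564000 nM, the only true number among them. Compound 2 `CC(C)CNc1nc(/C=C/c2ccccc2)nc2ccsc12` reads > 1000000 nM, which is a limit of the assay and not a number. Compound 3 `CNc1nc(/C=C/c2cc(OC)c(OC)c(OC)c2)nc2ccsc12` reads > 1000000 nM, which is also a limit. Compound 3 therefore stands at the limit of > 1000000 nM in this assay, at which 2 of the 3 values shown sit, and its true value is not known.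

Compound 4 `COc1cc(/C=C/c2nc(NC3CC3)c3sccc3n2)cc(OC)c1OC` has not yet been measured. It differs from compound 3 in one place: cyclopropyl in place of methyl on a nitrogen on an aromatic ring. In words, cyclopropyl takes the place of methyl on a nitrogen on an aromatic ring. For the measured compounds named here, no two measured compounds differ in just one place, so no measured step can serve as a guide. The expectation is a modest move towards stronger inhibition, or no change beyond the usual scatter, and compound 4 may well be reported only as a limit. For compound 1, the value of 564000 nM suggests that even a real reading here is likely to remain high. The estimated change is small, running an at least 1.4-fold lower number from compound 3 to compound 4 (0.15 log units; that floor lies within the scatter). Compound 4 is estimated at 700000 nM, with an expected range of 250000 nM to 1000000 nM.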

Compound 4, half-maximal inhibitory concentration: > 1000000 nM
Compound 4 ended at the assay's limit (the forecaster's own chance of this, stated with the estimate: 50%); at least 1.4-fold (0.15 log units) between middle value and limit.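

Compound 3 and compound 4 both read only as limits in this assay, so no step can be read from compound 3 to compound 4, and they join the others at one ceiling: the limit of > 1000000 nM in this assay, at which 3 of the 4 values shown sit. Left open is whether cyclopropyl in place of methyl changes inhibition at all, and how far beyond that limit either compound truly lies.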